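Swapping Methyl for Methoxy on the Aryl Alkyne

A few compounds are considered here, and "the series" means these few. Any claim that something is new, unique, unknown or untested is made for them only; others in the source may bear on it.

Of the compounds shown here, three sharing one core have been measured in an assay on HEK293 cells for displacement of a labelled ligand from metabotropic glutamate receptor 5 (Homo sapiens), with a stated time of 2 h; on this read-out lower numbers stand for stronger inhibition and higher numbers for weaker inhibition. Compound 1 `Cc1cccc(C#Cc2ccc3c(n2)CCN(C)C3=O)c1` gives 820 nM and holds the lowest number of the three. Compound 2 `Cc1ccc(C#Cc2ccc3c(n2)CCN(C)C3=O)cc1` gives 7450 nM, and compound 3 `CN1CCc2nc(C#Cc3ccc(Cl)cc3)ccc2C1=O` gives 6150 nM. The step of a 9.1-fold higher number from compound 1 to compound 2 (0.96 log units; beyond the scatter) and the step of a 7.5-fold higher number from compound 1 to compound 3 (0.88 log units; beyond the scatter) both replace the 3-methylphenyl of compound 1 with a 4-substituted ring, whereas the step of a 1.2-fold lower number from compound 2 to compound 3 (0.08 log units; within the scatter) exchanges only the group itself on an otherwise identical ring. Compound 4 `COc1cccc(C#Cc2ccc3c(n2)CCN(C)C3=O)c1` differs from compound 1 by methoxy in place of methyl on an aromatic carbon, a change that keeps the ring substitution pattern and alters only the group, which resembles the exchange between compound 2 and compound 3 rather than the two larger steps. Within the data shown here, no measured step covers methyl against methoxy directly, so the expectation rests on that analogy. The estimated step of a 1.2-fold higher number from compound 1 to compound 4 (0.09 log units; within the scatter) is therefore expected to stay within or only just beyond the scatter. Compound 4 is estimated at 1000 nM in this assay, with a range from 350 nM to 3000 nM.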

Compound 4, inhibition constant: 3660 nM
Compound 4: middle estimate off by 3.7-fold (0.56 log units), on the low side; the whole stated range lies below it.
By their numbers in this assay, from the lowest: compound 1; then compounds 4, 3 and 2 (each within the scatter of the next, the first and the last beyond it).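

In this assay, the exchange of methyl for methoxy, meta to a large group, gives a 4.5-fold higher number from compound 1 to compound 4 (0.65 log units; beyond the scatter) and leaves the ring substitution pattern untouched. Among these compounds, this shows that at this position a change of the group alone can move the number beyond the scatter, whereas the only earlier exchange of group alone, on the 4-substituted ring, gave a 1.2-fold lower number from compound 2 to compound 3 (0.08 log units; within the scatter) and stayed within it. Nothing measured on these groups accounts for the difference between the two exchanges.

The compounds shown leave open whether the loss follows from the added oxygen or from the larger group, which a fluoro, ethyl or hydroxy group on the same carbon could help to separate. They also leave open whether methoxy on the 4-substituted ring would behave as it does here.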